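The source may report more compounds than this note shows. Statements on the series, on what has been measured and on what is new or still open speak of the compounds shown alone.

Compound 1 (`Nc1cccc(Nc2c(C(=O)NCc3ccc(F)cc3)nc(Br)c3cccnc23)c1`) gives 8000 nM in a functional assay on LNCaP cells (Homo sapiens) for cytotoxicity, read by MTT assay, with a stated time of 72 h (on this read-out higher numbers stand for weaker inhibition and lower numbers for stronger inhibition), as its reading.
Compound 2 (`O=C(NCCCNc1c(C(=O)NCc2ccc(F)cc2)nc(Br)c2cccnc12)c1ccccc1`) gives > 10000 nM in this assay as its reading.

Compound 2 stands at a limit of the assay, with > 10000 nM as its entry, and not at a number. Within the data shown here, compound 1, with 8000 nM as its reading, supplies the one number for the shared core.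

In compound 3 (`COC(=O)CNc1c(C(=O)NCc2ccc(F)cc2)nc(Br)c2cccnc12`) methoxycarbonyl comes in place of 2-benzamidoethyl on a saturated chain carbon bound to a nitrogen on an aromatic ring (methoxycarbonyl in place of 2-benzamidoethyl on a saturated chain carbon bound to a nitrogen on an aromatic ring). Among the measured compounds shown here, no measured step shows what a change of this kind does in this assay for these compounds. The expectation therefore rests on compound 1 at 8000 nM as the nearest number available.

Only a small change is expected (a number no higher from compound 2 to compound 3 (the limit leaves the size open)) in this assay, with none beyond the scatter. The estimated value for compound 3 is 10000 nM (expected range 4000 nM to 25000 nM).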

Compound 3, half-maximal inhibitory concentration: 5000 nM
Estimate against measurement, compound 3: 2.0-fold (0.30 log units) above; measured number inside the range.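

Methoxycarbonyl in place of 2-benzamidoethyl on a saturated chain carbon bound to a nitrogen on an aromatic ring gives an at least 2.0-fold lower number from compound 2 to compound 3 (0.30 log units; that floor lies within the scatter) in this assay and is the only step read at this place. On these data alone, compound 2 gives > 10000 nM as a limit of the assay and not a number, so the true size of that step stays open: the limit of > 10000 nM in this assay, at which 1 of the 3 values shown sits. On a nitrogen on an aromatic ring, (methoxycarbonyl)methyl in place of 3-aminophenyl gives a 1.6-fold lower number from compound 1 to compound 3 (0.20 log units; within the scatter) and so does not tell these two groups apart in this reading.

The compounds shown leave open whether a carboxylic acid in place of methoxycarbonyl would move the number beyond the scatter. They also leave open what a longer chain or a terminal amine on that nitrogen would do.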